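Same Exchange, Second Core: What the First Step Suggests

The compounds below may be only part of what the source reports. "The series", "measured", "known", "first", "only" and "open" are said of these compounds alone.

Of the compounds shown here, three have been measured in an assay on CHO cells for antagonist activity at transient receptor potential cation channel subfamily V member 1 (Homo sapiens), read by FLIPR; on this read-out lower numbers stand for stronger inhibition and higher numbers for weaker inhibition.

Compound 1, `CC1CCN(c2nc(C(F)(F)Cl)ccc2CNC(=O)C(C)c2ccc(NS(C)(=O)=O)c(F)c2)CC1`, gives 0.3 nM.
Compound 2, `CCCCCCOc1nc(C(F)(F)Cl)ccc1CNC(=O)C(C)c1ccc(NS(C)(=O)=O)c(F)c1`, gives 0.8 nM.
Compound 3, `Cc1cc(C(F)(F)F)nc(N2CCC(C)CC2)c1CNC(=O)C(C)c1ccc(NS(C)(=O)=O)c(F)c1`, gives 17.5 nM.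

Compound 1 and compound 2 differ in one place only: hexyloxy in place of 4-methylpiperidin-1-yl on an aromatic carbon. That exchange made a 2.7-fold higher number from compound 1 to compound 2 (0.43 log units; beyond the scatter). Compound 3 carries the same 4-methylpiperidin-1-yl group as compound 1 but on a different core; the difference between the two cores is not broken down here. Compound 3 gives the highest number of the three.

Compound 4, `CCCCCCOc1nc(C(F)(F)F)cc(C)c1CNC(=O)C(C)c1ccc(NS(C)(=O)=O)c(F)c1`, is not yet measured. It stands to compound 3 as compound 2 stands to compound 1: hexyloxy in place of 4-methylpiperidin-1-yl on an aromatic carbon. The surroundings are not identical, though: in compound 3 the place is meta to a methyl group and meta to a trifluoromethyl group, whereas in compound 1 it is meta to a chloro(difluoro)methyl group. It is thus the same kind of change, not the same change.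

In this assay compound 4 is expected to show a 2.7-fold higher number from compound 3 to compound 4 (0.43 log units; beyond the scatter), because the same kind of change gave a 2.7-fold higher number from compound 1 to compound 2 (0.43 log units; beyond the scatter). The estimate for compound 4 is 47 nM, likely between 15 nM and 150 nM.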

Compound 4, inhibition constant: 100 nM
Estimate against measurement, compound 4: 2.1-fold (0.33 log units) below, within the range that was stated.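

In this assay, putting hexyloxy in place of 4-methylpiperidin-1-yl gave a 5.7-fold higher number from compound 3 to compound 4 (0.76 log units; beyond the scatter), and this step matches the earlier one as closely as repeated measurements would be expected to: the same change on two cores in this assay, a 2.7-fold higher number (0.43 log units; beyond the scatter) from compound 1 to compound 2 and a 5.7-fold higher number (0.76 log units; beyond the scatter) from compound 3 to compound 4, 2.1-fold (0.33 log units) apart, within the scatter of two such steps

On these two cores, then, the exchange moves the number the same way, towards weaker inhibition, and its size carries over from one core to the other within the scatter. Two pairs cannot show that this would hold on a further core, and they say nothing about why the exchange has this effect.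

The compounds shown do not separate the parts of the core: whether the added methyl group or trifluoromethyl in place of chloro(difluoro)methyl goes with the higher numbers of compound 3 and compound 4 remains open. Also open, from the compounds shown here alone, is how a shorter ether chain or an open-chain amine in the same place would compare with hexyloxy and 4-methylpiperidin-1-yl.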